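From a Pentyl Chain to a Carbamoyl End

The compounds below may be only part of what the source reports. "The series", "measured", "known", "first", "only" and "open" are said of these compounds alone.

Measured in an ADME assay on CEM-SS cells (Homo sapiens) for cytotoxicity, read by XTT assay, with a stated time of 6 days; a lower number here means that less compound is tolerated, a higher number that more compound is tolerated:
Compound 1 `CCCC(=O)OCSc1ccccc1C(=O)NCCCC(N)=O`: 56.6 uM
Compound 2 `CCCC(=O)OCSc1ccccc1C(N)=O`: 12.4 uM
Compound 3 `CCCCCNC(=O)CNC(=O)c1ccccc1SCOC(=O)CCC`: 24.8 uM

Compound 3 lies clearly lower than compound 1, while its gap to compound 2 stays within the scatter. Compound 4 `CCCC(=O)OCSc1ccccc1C(=O)NCC(=O)NCC(N)=O` has not been measured yet. It differs from compound 3 by carbamoyl in place of butyl on a saturated chain carbon bound to an amide-type nitrogen. Cut one bond further out, this reads pentylcarbamoyl to (carbamoylmethyl)carbamoyl.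

Going by the values given here, two measured steps bear on this change. The closer one is a 2.3-fold lower number from compound 1 to compound 3 (0.36 log units; beyond the scatter), where a chain with a carbamoyl end gave way to one with a pentyl end. Compound 4 goes the other way, regaining a carbamoyl end. The second, a 4.6-fold lower number from compound 1 to compound 2 (0.66 log units; beyond the scatter), removed the 3-carbamoylpropyl chain entirely, so it is a looser guide. Both point to a modest rise in this assay when a carbamoyl end is present. The expected change is a 2.0-fold higher number from compound 3 to compound 4 (0.30 log units; within the scatter). The estimate for compound 4 is 50 uM, with an expected range of 22 uM to 115 uM.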

Compound 4, half-maximal toxic concentration: > 100 uM
Compound 4: a limit, no number; the forecaster's own chance of this, stated with the estimate: 10%; at least 2.0-fold (0.30 log units) between middle value and limit.
By their numbers in this assay, from the lowest: compounds 2 and 3 (each within the scatter of the next); then compound 1. At a limit, above all of these: compound 4.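

In this assay compound 4 stands at a limit of the assay, not at a number: the limit of > 100 uM in this assay, at which 1 of the 4 values shown sits. Swapping the pentylcarbamoyl end for (carbamoylmethyl)carbamoyl gives an at least 4.0-fold higher number from compound 3 to compound 4 (0.60 log units; beyond the scatter) and shows that, on this saturated chain carbon bound to an amide-type nitrogen, a carbamoyl end in place of butyl raises the tolerated concentration beyond the scatter. Measured against the unsubstituted amide, there is an at least 8.0-fold higher number from compound 2 to compound 4 (0.90 log units; beyond the scatter) and the rise is again clear, whereas an at least 1.7-fold higher number from compound 1 to compound 4 (0.24 log units; that floor lies within the scatter) and that floor leaves the real distance between these two compounds unsettled.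

Going by these compounds, how far the number of compound 4 lies past its limit remains unknown. Also open, on these data alone, is whether a carboxylic acid or an amine at the chain end, or a longer chain ending in carbamoyl, would hold the number this high.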